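The source may report more compounds than this note shows. Statements on the series, on what has been measured and on what is new or still open speak of the compounds shown alone.

Measured in a functional assay on A2780 cells (Homo sapiens) for antiproliferative activity, read by fluorescence, with a stated time of 72 h; on this read-out higher numbers stand for weaker inhibition and lower numbers for stronger inhibition:

- Compound 1 `CCCNC(=O)Nc1n[nH]c2c1CN(C(=O)C1CCN(C)CC1)C2(C)C`: 650 nM
- Compound 2 `CC(C)CC(=O)Nc1n[nH]c2c1CN(C(=O)C1CCN(C3CC3)CC1)C2(C)C`: 320 nM
- Compound 3 `CCN1CCC(C(=O)N2Cc3c(NC(=O)c4ccc(F)cc4)n[nH]c3C2(C)C)CC1`: 290 nM

On these three numbers compound 1 stands with the highest value, so the weakest inhibition of the set. Compound 2 and compound 3 both give lower numbers than compound 1, and in each case the gap lies beyond the usual scatter of this assay; the two of them sit within the scatter of each other, so no order between them can be read. Compound 2 and compound 3 differ from compound 1 in more than one place, so nothing single can be taken from their values.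

The step of interest leads from compound 1 to compound 4 `CN1CCC(C(=O)N2Cc3c(NC(=O)C4CC4)n[nH]c3C2(C)C)CC1`, an unmeasured compound. The change is cyclopropyl in place of propylamino on a carbonyl carbon; read one bond further out, propylcarbamoyl becomes cyclopropylcarbonyl. Among the measured compounds shown here, no step between measured compounds isolates this change. For the measured compounds named here, the only guide is that the two compounds carrying a carbonyl-linked group without the propylamino piece, compound 2 and compound 3, both give lower numbers than compound 1. An estimated step of a 1.6-fold lower number from compound 1 to compound 4 (0.21 log units; within the scatter) toward a somewhat lower number is therefore expected in this assay, modest and uncertain. Compound 4 is accordingly estimated at 400 nM, within a range from 150 nM to 1200 nM.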

Compound 4, half-maximal inhibitory concentration: 1420 nM
Compound 4: the middle estimate sits 3.6-fold (0.55 log units) below what was measured, outside the stated range (above it).
By their numbers in this assay, from the lowest: compounds 3 and 2 (each within the scatter of the next); then compound 1; then compound 4.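

In this assay, among the compounds shown here, cyclopropyl in place of propylamino on a carbonyl carbon gives a 2.2-fold higher number from compound 1 to compound 4 (0.34 log units; beyond the scatter) and so weaker inhibition, which is the first step in this set that isolates a single change. It shows that the group on this carbonyl carbon bears on the read-out, and that in this pair, replacing propylamino with cyclopropyl does not lower the number. Nothing available explains why the number rises.

The compounds shown leave open whether the step follows from losing the nitrogen of propylamino or from bringing in the three-membered ring, since both change together here. A cyclopropylamino group or a plain propyl chain on the same carbonyl carbon would separate the two.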